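A few compounds are considered here, and "the series" means these few. Any claim that something is new, unique, unknown or untested is made for them only; others in the source may bear on it.

Compound 1 `CC(=O)c1c(O)ccc2oc(-c3ccccc3)nc12` and compound 2 `Cc1ccccc1-c1nc2c(C=O)c(O)ccc2o1` share one core and differ in two places. In an ADME assay on HaCaT cells (Homo sapiens) for cytotoxicity, read by MTT assay, with a stated time of 48 h (a lower number here means a stronger inhibitor, a higher number a weaker inhibitor), compound 1 reports only a limit, > 30000 nM. Among the two values shown, compound 2 gives the only number, 12200 nM in this assay. Compound 1 stands at the limit of > 30000 nM in this assay, at which 1 of the 2 values shown sits. Compound 3 `CC(=O)c1c(O)ccc2oc(-c3ccccc3C)nc12` is not yet measured; it differs from compound 2 by methyl in place of hydrogen on a carbonyl carbon. Among the measured compounds shown here, no measured pair shows this change, so the step from compound 2 to compound 3 is expected to be a 2.0-fold higher number from compound 2 to compound 3 (0.31 log units; beyond the scatter), toward weaker inhibition. Compound 3 is estimated at 25000 nM, between 10000 nM and 60000 nM.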

Compound 3, half-maximal inhibitory concentration: 8940 nM
The estimate for compound 3 lay 2.8-fold (0.45 log units) above the measured number, outside the stated range (below it).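

In this assay, formyl to acetyl on the carbonyl carbon gives a 1.4-fold lower number from compound 2 to compound 3 (0.14 log units; within the scatter), so this pair shows no readable change at this position. Methyl in place of hydrogen on an aromatic carbon gives an at least 3.3-fold lower number from compound 1 to compound 3 (0.52 log units; beyond the scatter), the only step here that lies beyond the scatter. Compound 1 gives only a limit, > 30000 nM.

The compounds shown leave open how a longer chain, an amine or a carboxylic acid on the carbonyl carbon would read. They also leave open whether ethyl or chlorine on that aromatic carbon would match methyl.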